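The source may hold more compounds than are shown below. What is called first, only, known or untested is meant among the compounds shown, and "the series" means these compounds.

Working notes on the series in a functional assay on A549 cells (Homo sapiens) for inhibition, read by CCK-8 assay, with a stated time of 48 h; a higher number here means a weaker inhibitor, a lower number a stronger inhibitor. Compound 1 (`COc1cc(-c2ccnc3cc(-c4ccc(C)c(C)c4)nn23)cc(OC)c1OC`) gives 272 nM and compound 2 (`COc1cc(-c2ccnc3cc(-c4ccc(C(C)=O)cc4)nn23)cc(OC)c1OC`) gives 4100 nM. Compound 3 (`COc1cc(-c2ccnc3cc(-c4ccc(-c5cnn(C)c5)cc4)nn23)cc(OC)c1OC`) gives 1150 nM, the middle of the three numbers. Compound 4 (`COc1cc(-c2ccnc3cc(-c4ccc(C(C)(C)C)cc4)nn23)cc(OC)c1OC`) has tert-butyl in place of 1-methyl-1H-pyrazol-4-yl on an aromatic carbon. Within the data shown here, no measured step makes this exact exchange. The large step of a 15-fold higher number from compound 1 to compound 2 (1.18 log units; beyond the scatter) and the modest step of a 3.6-fold lower number from compound 2 to compound 3 (0.55 log units; beyond the scatter) both bear on it, as changes at the same ring. Of the three, only compound 1 at 272 nM carries plain alkyl groups there, so a modest move to a lower number is expected. The expected change is a 2.3-fold lower number from compound 3 to compound 4 (0.36 log units; beyond the scatter). For compound 4 the estimated value is 500 nM, with an expected range of 170 nM to 1300 nM.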

Compound 4, half-maximal inhibitory concentration: > 10000 nM
Compound 4 ended at the assay's limit (the forecaster's own chance of this, stated with the estimate: 2%); middle value at least 20-fold (1.30 log units) away from the limit.
By their numbers in this assay, from the lowest: compound 1; then compound 3; then compound 2. At a limit, above all of these: compound 4.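

In this assay compound 4 gives > 10000 nM, which is a limit and not a number: the limit of > 10000 nM in this assay, at which 1 of the 4 values shown sits.

A plain alkyl group on this ring therefore does not by itself keep the number low, as shown by an at least 36-fold higher number from compound 1 to compound 4 (1.56 log units; beyond the scatter). Tert-butyl at this place also compares poorly with the other para groups, with an at least 8.6-fold higher number from compound 3 to compound 4 (0.93 log units; beyond the scatter) and an at least 2.4-fold higher number from compound 2 to compound 4 (0.38 log units; beyond the scatter).

From the compounds shown here alone, how an amine, a carboxylic acid or a longer chain would read at this place stays open. So does how far past its limit compound 4 lies.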